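The source may report more compounds than this note shows. Statements on the series, on what has been measured and on what is new or still open speak of the compounds shown alone.

In a functional assay on SK-MEL-28 cells (Homo sapiens) for inhibition, read by sulforhodamine B assay, with a stated time of 48 h, tested at 10 uM (a higher number here means a weaker effect of the compound at the concentration tested, a lower number a stronger effect), compound 2 `COc1cc(Cl)cc(-c2nn(-c3cccc(NC(=O)c4cccc(C(F)(F)F)c4)c3)cc2-c2ccncc2)c1` gives 70.4%, the lowest of the two numbers measured. Compound 1 `COc1cc(Cl)cc(-c2nn(-c3cccc(NC(=O)c4ccc(Cl)c(Cl)c4)c3)cc2-c2ccncc2)c1` gives 87.8%, and the step of a number 17.4 percentage points lower from compound 1 to compound 2 (beyond the scatter) lies beyond the scatter. Compound 3 `COc1cc(Cl)cc(-c2nn(-c3cccc(NC(=O)c4cc(C(F)(F)F)cc(C(F)(F)F)c4)c3)cc2-c2ccncc2)c1` differs from compound 2 by trifluoromethyl in place of hydrogen on an aromatic carbon. Among the compounds with values here, no measured step swaps a hydrogen for a trifluoromethyl, so the measured step from compound 1 to compound 2, modest in size, bears only indirectly on this change. Compound 3 is therefore expected to move by a number 8.4 percentage points lower from compound 2 to compound 3 (within the scatter), a step not clearly beyond the scatter. The estimate for compound 3 in this assay is 62%, between 35% and 90%.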

Compound 3, a percentage reported as activity, at one concentration (the size of the read-out at that concentration, not a potency): 78.8%
Estimate against measurement, compound 3: 16.8 percentage points below; measured number inside the range.
By their numbers in this assay, from the lowest: compounds 2, 3 and 1 (each within the scatter of the next, the first and the last beyond it).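

In this assay, trifluoromethyl in place of hydrogen on this aromatic carbon, meta to a trifluoromethyl group, gives a number 8.4 percentage points higher from compound 2 to compound 3 (within the scatter). At this position, then, the hydrogen and the added trifluoromethyl cannot be told apart in this read-out, even though the entering group brings 4 heavy atoms. Nothing available offers a reason for this result. From the compounds shown here alone, it remains open whether an amine or a carboxylic acid on this same carbon would give a step beyond the scatter, and whether a methoxy group would behave as trifluoromethyl does here.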